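The compounds below may be only part of what the source reports. "The series", "measured", "known", "first", "only" and "open" are said of these compounds alone.

Measured so far:
compound 1, `CCCOc1ccc(C)c(-c2cccc(COc3ccc(OCC(=O)O)c(F)c3)c2)c1`, 610 nM in a functional assay on CHO cells for agonist activity at Free fatty acid receptor 1 (Homo sapiens), read by FLIPR and calcium flux; a lower number here means that less compound is needed, a higher number that more compound is needed for the effect;
compound 2, `Cc1ccc(OCC2CC2)cc1-c1cccc(COc2ccc(OCC(=O)O)c(F)c2)c1`, 340 nM in this assay.

Compound 2 shows the lower of the two numbers, but the step of a 1.8-fold lower number from compound 1 to compound 2 (0.25 log units; within the scatter) lies within the scatter, so the two compounds cannot be told apart on these data. Compound 3, `Cc1ccc(OCC2CCCC2)cc1-c1cccc(COc2ccc(OCC(=O)O)c(F)c2)c1`, has not yet been measured. It differs from compound 2 by cyclopentyl in place of cyclopropyl on a saturated chain carbon bound to an oxygen on an aromatic ring. Going by the values given here, the only measured step touching this position, a 1.8-fold lower number from compound 1 to compound 2 (0.25 log units; within the scatter), also exchanged the group on that chain carbon and did not leave the scatter. A further change at the same place is therefore expected to shift the number only modestly, if at all, with a slight lean toward a lower value. For compound 3 the expected result in this assay is 230 nM, within a range of 90 nM to 600 nM, corresponding to an expected step of a 1.5-fold lower number from compound 2 to compound 3 (0.17 log units; within the scatter).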

Compound 3, half-maximal effective concentration: 490 nM
Compound 3: the middle estimate sits 2.1-fold (0.33 log units) below what was measured; the range from low to high includes it.
By their numbers in this assay, from the lowest: compounds 2, 3 and 1 (each within the scatter of the next).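

The chain carbon bound to the oxygen on the aromatic ring has now carried three different groups, and in this assay every new step stays within the scatter: cyclopentyl in place of cyclopropyl gives (a 1.4-fold higher number from compound 2 to compound 3 (0.16 log units; within the scatter)), and cyclopentyl in place of ethyl gives (a 1.2-fold lower number from compound 1 to compound 3 (0.10 log units; within the scatter)). Going from a three-membered to a five-membered carbon ring therefore produces no readable change, and compounds 1, 2 and 3 cannot be told apart, so no trend with ring size can be claimed. No supporting measurement bears on this result.

These three compounds carry only carbon groups at this place, so they leave open what a group holding an amine, a hydroxyl or a phenyl ring would do there. They also leave open whether a much longer chain would move the number beyond the scatter.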